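Oxazole in Place of Isopropylcarbamoyl: An Expected Step

A few compounds are considered here, and "the series" means these few. Any claim that something is new, unique, unknown or untested is made for them only; others in the source may bear on it.

Compound 1 `COC(=O)C1=C(C)NC(=O)NC1c1ccoc1` and compound 2 `CC1=C(C(=O)NC(C)C)C(c2ccoc2)NC(=O)N1` share one core and differ at a single carbonyl carbon, where compound 2 carries isopropylamino in place of methoxy. In an assay on membranes from CHO cells for displacement of a labelled ligand from adenosine receptor A1 (Homo sapiens), read by scintillation counting, with a stated time of 60 min, tested at 1 uM (a lower number here means less inhibition, a higher number more inhibition at the concentration tested (going by the name of the read-out)), compound 1 gives 8% and compound 2 gives 1%; the step of a number 7 percentage points lower from compound 1 to compound 2 (within the scatter) lies within the scatter, so the two numbers cannot be ordered. Compound 2 thus stands at the lower of the two values recorded, its nearest neighbour being compound 1, with a difference that is within the scatter.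

Compound 3 `CC1=C(c2ncc(C)o2)C(c2ccoc2)NC(=O)N1` has not been measured. It differs from compound 2 by 5-methyl-1,3-oxazol-2-yl in place of isopropylcarbamoyl on a double-bonded ring carbon. Among the compounds with values here, no measured step involves a change of this kind: the only step recorded, a number 7 percentage points lower from compound 1 to compound 2 (within the scatter), alters a group on the carbonyl that is itself removed here, and it was within the scatter. Within the data shown here, because compound 2 gives 1% and the only recorded step a number 7 percentage points lower from compound 1 to compound 2 (within the scatter) stayed within the scatter, the expectation for compound 3 in this assay is a step of a number 4 percentage points higher from compound 2 to compound 3 (within the scatter) that remains within the scatter. Compound 3 is therefore estimated at 5%, with a range from -8% to 22%.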

Compound 3, a percentage reported as inhibition, at one concentration (the size of the read-out at that concentration, not a potency): 21%
The estimate for compound 3 lay 16 percentage points below the measured number; the measured number falls inside the stated range.
By their numbers in this assay, from the lowest: compounds 2 and 1 (each within the scatter of the next); then compound 3.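

In this assay, this double-bonded ring carbon turns out to be a place where a change can move the read-out beyond the scatter: 5-methyl-1,3-oxazol-2-yl in place of isopropylcarbamoyl gives a number 20 percentage points higher from compound 2 to compound 3 (beyond the scatter), and the same group in place of methoxycarbonyl gives a number 13 percentage points higher from compound 1 to compound 3 (beyond the scatter). The step from isopropylcarbamoyl comes with no change in the count of heavy atoms or in their elements, while the open group with its hydrogen-bond donor gives way to a five-membered aromatic ring with none. The compounds shown come with no evidence that accounts for this rise.

Going by these compounds, it stays open which part of the new group goes with the step, and what an unsubstituted 1,3-oxazol-2-yl or a 1,3-thiazol-2-yl group would give on this carbon. Also open, on these data alone, are whether the step holds with a phenyl group in place of the furan-3-yl group, and what potency lies behind a read-out taken at one concentration.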